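A Chloro Step Repeated on a Hydroxyphenyl Hydrazone

A few compounds are considered here, and "the series" means these few. Any claim that something is new, unique, unknown or untested is made for them only; others in the source may bear on it.

Compound 1 `O=C(CSc1nnc(-c2ccncc2)o1)N/N=C/c1ccccc1` gives 17300 nM in a functional assay on HepG2 cells (Homo sapiens) for cytotoxicity, read by MTT assay, with a stated time of 48 h; a higher number here means a weaker inhibitor, a lower number a stronger inhibitor. Compound 2 `O=C(CSc1nnc(-c2ccncc2)o1)N/N=C/c1ccc(Cl)cc1` differs from it by chloro in place of hydrogen on an aromatic carbon and gives 15700 nM in this assay, a step of a 1.1-fold lower number from compound 1 to compound 2 (0.04 log units; within the scatter). Compound 3 `O=C(CSc1nnc(-c2ccncc2)o1)N/N=C/c1ccccc1O` differs from compound 1 by hydroxy in place of hydrogen on an aromatic carbon; in this assay compound 3 gives 3510 nM, the step being a 4.9-fold lower number from compound 1 to compound 3 (0.69 log units; beyond the scatter) and, from compound 2, a 4.5-fold lower number from compound 2 to compound 3 (0.65 log units; beyond the scatter). Compound 4 `O=C(CSc1nnc(-c2ccncc2)o1)N/N=C/c1cc(Cl)ccc1O` is not yet measured and differs from compound 3 by chloro in place of hydrogen on an aromatic carbon. This is the same kind of change as that from compound 1 to compound 2, though there the chloro group sits para to a large group, while here it sits meta to a large group and para to a hydroxy group. For compound 4 the expected step in this assay is a 1.2-fold lower number from compound 3 to compound 4 (0.07 log units; within the scatter), because the matching measured step is a 1.1-fold lower number from compound 1 to compound 2 (0.04 log units; within the scatter). Compound 4 is therefore estimated at 3000 nM, between 1200 nM and 7500 nM.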

Compound 4, half-maximal inhibitory concentration: 3970 nM
The estimate for compound 4 lay 1.3-fold (0.12 log units) below the measured number; the measured number falls inside the stated range.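

In this assay, adding chloro to the hydroxyphenyl hydrazone gives a 1.1-fold higher number from compound 3 to compound 4 (0.05 log units; within the scatter), and this step matches the one on the core of compound 1: the same change on two cores in this assay, a 1.1-fold lower number (0.04 log units; within the scatter) from compound 1 to compound 2 and a 1.1-fold higher number (0.05 log units; within the scatter) from compound 3 to compound 4, 1.2-fold (0.10 log units) apart, within the scatter of two such steps. The two hydroxy-bearing compounds stay apart from the others, with a 4.0-fold lower number from compound 2 to compound 4 (0.60 log units; beyond the scatter) and a 4.4-fold lower number from compound 1 to compound 4 (0.64 log units; beyond the scatter). This shows that the chloro change carries over between these two cores with no step beyond the scatter, but it covers only these two cores and two placements of the chloro group, and it does not show the same for any other core or position.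

The compounds shown leave open whether an amine or a carboxylic acid in place of the chloro group would shift the number. They also leave open whether a methoxy group in place of the hydroxy group would keep the lower numbers seen for compound 3 and compound 4.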